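A few compounds are considered here, and "the series" means these few. Any claim that something is new, unique, unknown or untested is made for them only; others in the source may bear on it.

Three compounds share one core and differ only in the substitution of the six-membered aromatic ring of carbon only. Compound 1 `CNC(=O)c1ccc(CN(C)C(=O)c2cc(Cl)c(O)cc2O)cc1` gives 34800 nM in a functional assay on NCI-H1975 cells (Homo sapiens) for antiproliferative activity, with a stated time of 72 h; on this read-out higher numbers stand for weaker inhibition of growth and lower numbers for stronger inhibition of growth. Compound 2 `COc1cc(CN(C)C(=O)c2cc(Cl)c(O)cc2O)cc(OC)c1OC` gives 73100 nM in this assay, and compound 3 `COc1ccc(CN(C)C(=O)c2cc(Cl)c(O)cc2O)cc1` gives 16700 nM in this assay. Compound 3 thus has the lowest number of the three; the step of a 2.1-fold lower number from compound 1 to compound 3 (0.32 log units; beyond the scatter) separates it from compound 1, and compound 2 sits further off. Compound 4 `COc1ccc(CN(C)C(=O)c2cc(Cl)c(O)cc2O)cc1OC` follows from compound 3 by one change: methoxy in place of hydrogen on an aromatic carbon. Within the data shown here, no measured step shows exactly this change. Among the measured compounds shown here, the only single-place step, a 2.1-fold lower number from compound 1 to compound 3 (0.32 log units; beyond the scatter), concerns a different exchange on the same ring. Compound 2 carries additional methoxy groups relative to compound 3 and gives a higher number, and compound 4 lies between them in that respect, so a moderately higher number is expected, though a result within the scatter cannot be excluded. Compound 4 is expected at 30000 nM in this assay, with a range of 12000 nM to 80000 nM. That corresponds to an expected step of a 1.8-fold higher number from compound 3 to compound 4 (0.25 log units; within the scatter).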

Compound 4, concentration for 50% growth inhibition: 33400 nM
Compound 4: middle estimate off by 1.1-fold (0.05 log units), on the low side; measured number inside the range.
By their numbers in this assay, from the lowest: compounds 3, 4 and 1 (each within the scatter of the next, the first and the last beyond it); then compound 2.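

The step that isolates this position, a 2.0-fold higher number from compound 3 to compound 4 (0.30 log units; within the scatter) in this assay, lies within the scatter, so a methoxy in place of hydrogen, ortho to a methoxy group, cannot be told apart from hydrogen on this read-out. The step of a 2.2-fold lower number from compound 2 to compound 4 (0.34 log units; beyond the scatter), with hydrogen in place of methoxy, lies beyond the scatter but is modest, so taking one methoxy off the ring of compound 2 does register in this assay. Nothing measured here gives a reason for either step.

Going by these compounds, it remains open whether another group at this position, such as an amine, a carboxylic acid or a longer chain like butoxy, would shift the number more clearly. On these data alone, it is also open whether a methoxy here would behave the same on a ring without the existing methoxy group.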